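A few compounds are considered here, and "the series" means these few. Any claim that something is new, unique, unknown or untested is made for them only; others in the source may bear on it.

Measured compounds:
Compound 1, `N#CC1=C(N)Oc2c(N)cc3nc4ccccc4nc3c2C12C(=O)N(Cc1cnnn1-c1ccccc1Br)c1ccccc12`, gives 27400 nM in a functional assay on A549 cells (Homo sapiens) for antiproliferative activity, read by MTT assay, with a stated time of 48 h; a lower number here means a stronger inhibitor, a higher number a weaker inhibitor.
Compound 2, `CCOc1ccc(-n2nncc2CN2C(=O)C3(C(C#N)=C(N)Oc4c(N)cc5nc6ccccc6nc5c43)c3ccccc32)cc1`, gives > 50000 nM in this assay.

The value of compound 2 in this assay is a limit of the assay, not a number. Compound 2 is the one of the two measured compounds that sits at the limit of > 50000 nM in this assay, at which 1 of the 2 values shown sits, so it stands at the weak end of what this assay reports. Among the measured compounds shown here, the only measured step varies the same place that is varied next: an at least 1.8-fold higher number from compound 1 to compound 2 (0.26 log units; that floor lies within the scatter). Because its floor lies within the scatter, this step gives only a weak pointer.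

Compound 3, `N#CC1=C(N)Oc2c(N)cc3nc4ccccc4nc3c2C12C(=O)N(Cc1cnnn1-c1ccc(Cl)cc1Cl)c1ccccc12`, differs from compound 2 in one place: 2,4-dichlorophenyl in place of 4-ethoxyphenyl on an aromatic nitrogen. Compound 1 carries a halogen-bearing ring, 2-bromophenyl, on that same aromatic nitrogen and gives 27400 nM. A halogen-bearing ring is expected to bring compound 3 back toward the number seen for compound 1, so the expected step is an at least 1.6-fold lower number from compound 2 to compound 3 (0.22 log units; that floor lies within the scatter). Compound 3 is therefore estimated at 30000 nM, with a range from 12000 nM to 60000 nM.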

Compound 3, half-maximal inhibitory concentration: > 50000 nM
Compound 3 was reported as a limit; the forecaster's own chance of this, stated with the estimate: 35%; middle value at least 1.6-fold (0.22 log units) from the limit.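

In this assay, compound 3 joins compound 2 at the limit of what the assay reports, so its value is a limit and not a number: the limit of > 50000 nM in this assay, at which 2 of the 3 values shown sit.

The change from 2-bromophenyl to 2,4-dichlorophenyl on the aromatic nitrogen gives an at least 1.8-fold higher number from compound 1 to compound 3 (0.26 log units; that floor lies within the scatter), so this step, like the earlier one to 4-ethoxyphenyl, is only a weak pointer. Compound 3 shows that a halogen-bearing ring at this position does not by itself give a measured number, even though compound 1 has one, while the step between the two limits of compound 2 and compound 3 cannot be read.

On these data alone, the true numbers of compound 2 and compound 3 remain unknown, so these two compounds cannot be placed in order, and only compound 1 has a measured number in this set. As far as these compounds go, it also remains open whether a ring carrying an amine or a carboxylic acid at this position, or a benzyl group in place of the ring, would give a clearly lower number than compound 1.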